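The compounds below may be only part of what the source reports. "The series", "measured", "known", "first", "only" and "open" are said of these compounds alone.

Measured so far in a functional assay on A-375 cells (Homo sapiens) for cytotoxicity, read by MTT assay; on this read-out higher numbers stand for weaker inhibition and lower numbers for stronger inhibition:
- compound 1 `COc1ccc(/C=C/C(=O)c2ccc(OC)c3c2OC(C)(C)C=C3)cc1O`: 800 nM
- compound 2 `CCC(=O)Oc1cc(/C=C/C(=O)c2ccc(OC)c3c2OC(C)(C)C=C3)ccc1OC`: 240 nM
- compound 3 `CCCCC(=O)Oc1cc(/C=C/C(=O)c2ccc(OC)c3c2OC(C)(C)C=C3)ccc1OC`: 220 nM

Compound 3 stands level with compound 2, with a 1.1-fold lower number from compound 2 to compound 3 (0.04 log units; within the scatter), and both lie clearly under compound 1. The step that counted was replacing the hydrogen on the oxygen, seen as a 3.3-fold lower number from compound 1 to compound 2 (0.52 log units; beyond the scatter) for propanoyl and a 3.6-fold lower number from compound 1 to compound 3 (0.56 log units; beyond the scatter) for butylcarbonyl. Both are modest.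

The next compound is compound 4 `COc1ccc(/C=C/C(=O)c2ccc(OC)c3c2OC(C)(C)C=C3)cc1OC(=O)C1CC1`, with cyclopropyl in place of butyl on a carbonyl carbon. The closest evidence is the change from propanoyl to butylcarbonyl, which moved the number by no more than the scatter in a 1.1-fold lower number from compound 2 to compound 3 (0.04 log units; within the scatter). Within the data shown here, no measured compound yet carries a ring at this place, so this is an extrapolation and the range stays wide.

In this assay the expected result is no shift beyond the scatter, estimated as a 1.1-fold higher number from compound 3 to compound 4 (0.06 log units; within the scatter). For compound 4 the estimated value is 250 nM, with an expected range of 110 nM to 550 nM.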

Compound 4, half-maximal inhibitory concentration: 380 nM
Compound 4: the middle estimate sits 1.5-fold (0.18 log units) below what was measured; the measured number falls inside the stated range.
By their numbers in this assay, from the lowest: compounds 3, 2 and 4 (each within the scatter of the next); then compound 1.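

In this assay a ring on the carbonyl carbon cannot be told apart from the open chains at this place: a 1.7-fold higher number from compound 3 to compound 4 (0.24 log units; within the scatter) and a 1.6-fold higher number from compound 2 to compound 4 (0.20 log units; within the scatter) both stay within the scatter. Replacing the hydrogen on the oxygen still counts with cyclopropylcarbonyl, with a 2.1-fold lower number from compound 1 to compound 4 (0.32 log units; beyond the scatter) lying beyond the scatter but modest, so this step is no longer tied to open-chain groups. Nothing available explains these results.

As far as these compounds go, a longer chain, a larger ring such as cyclohexyl or a phenyl group on the carbonyl carbon remains open, as does whether any of them would separate from the ethyl, butyl and cyclopropyl compounds. Also open, from the compounds shown here alone, is what a carbamate or an amide linkage would do in place of the ester.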